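The source may hold more compounds than are shown below. What is called first, only, known or untested is meant among the compounds shown, and "the series" means these compounds.

Compound 1 `C/C(=C\CC/C(C)=C/CC[C@@H]1[C@@]2(C)CCC(=O)C(C)(C)[C@H]2CC[C@@]1(C)O)CC/C=C(\C)C(=O)OCc1cn(-c2cccc([N+](=O)[O-])c2)nn1` was tested in a functional assay on DU-145 cells (Homo sapiens) for antiproliferative activity, read by MTT assay, with a stated time of 48 h; a lower number here means a stronger inhibitor, a higher number a weaker inhibitor. In this assay compound 1 gives only a limit, > 150000 nM, and not a number. Compound 2 `C/C(=C\CC/C(C)=C/CC[C@@H]1[C@@]2(C)CCC(=O)C(C)(C)[C@H]2CC[C@@]1(C)O)CC/C=C(\C)C(=O)OCc1cn(C[C@@H]2O[C@H](n3ccc(=O)[nH]c3=O)[C@H]3OC(C)(C)O[C@H]32)nn1` also gives only a limit in this assay, > 150000 nM. Every value known here sits at that same point: the limit of > 150000 nM in this assay, at which 2 of the 2 values shown sit. Compound 3 `C/C(=C\CC/C(C)=C/CC[C@@H]1[C@@]2(C)CCC(=O)C(C)(C)[C@H]2CC[C@@]1(C)O)CC/C=C(\C)C(=O)OCc1cn(-c2ccccc2F)nn1` is still unmeasured; it differs from compound 1 by 2-fluorophenyl in place of 3-nitrophenyl on an aromatic nitrogen. Going by the values given here, no measured step between compounds is known, so in this assay the change is expected to move the value no further than the scatter, and the expected step that the limit leaves unreadable from compound 1 to compound 3 is close to none. Compound 3 is estimated at 200000 nM, between 80000 nM and 500000 nM, most likely again only as a limit.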

Compound 3, half-maximal inhibitory concentration: > 150000 nM
Compound 3: a limit, no number (the forecaster's own chance of this, stated with the estimate: 80%); the middle value is on the limit's open side.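

Going by these compounds alone, compound 1 and compound 3 each give only a limit in this assay, and no step between them can be read. The compounds shown leave open whether any change to the shared core would give a measurable value: the limit of > 150000 nM in this assay, at which 3 of the 3 values shown sit.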